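Swapping 3,4-Difluorophenyl for 3-Cyanophenyl in Compound 3

The source may report more compounds than this note shows. Statements on the series, on what has been measured and on what is new or still open speak of the compounds shown alone.

Compound 1 `O=C(Nc1cc(F)cc(F)c1)N1CCC2(CC1)C(=O)N(c1ccc(F)c(Cl)c1)C2c1ccccn1`: 99.9%
Compound 2 `O=C(Nc1ccc(F)c(F)c1)N1CCC2(CC1)C(=O)N(c1cccc(Cl)c1)C2c1ccccn1`: 99.9%

Of the compounds shown here, two have been measured in an ADME assay on a cell-free system (plasma, Homo sapiens) for protein binding, with Plasma (Rattus norvegicus) as the target, so far. There compound 2 gives 99.9% and stands level with compound 1 at the digits shown, within the scatter. Among the measured compounds shown here, compound 3 `N#Cc1cccc(NC(=O)N2CCC3(CC2)C(=O)N(c2cccc(Cl)c2)C3c2ccccn2)c1` keeps the core of compound 2 and carries 3-cyanophenyl in place of 3,4-difluorophenyl on an amide-type nitrogen as its only change. For the measured compounds named here, neither measured compound carries a nitrile, and no measured step speaks directly to this exchange, so the expectation is a cautious one. With compound 2 at 99.9% as the starting point, the estimated step a 5.0-fold higher unbound fraction from compound 2 to compound 3 (0.70 log units; beyond the scatter) is a small one toward more free compound and may stay within the scatter. The estimate for compound 3 is 99.5% with a range of 98.5% to 99.9% in this assay once it is measured.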

Compound 3, plasma protein binding: 98.7%
Compound 3: the middle estimate sits 2.6-fold (0.41 log units) (unbound fraction) below what was measured, within the range that was stated.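

Among the compounds shown here, until now no step between compounds differing in one place was available in this assay, and this first one shows that the group on the amide-type nitrogen can move the read-out: 3-cyanophenyl in place of 3,4-difluorophenyl gives a 13-fold higher unbound fraction from compound 2 to compound 3 (1.11 log units; beyond the scatter) on an unchanged core. Both groups hold 8 heavy atoms, so the shift comes with no change in that count, and compound 3 gives 98.7%. Nothing measured here accounts for the size of this step.

Whether the rise in free compound goes with the entering nitrile or with the departing fluorines stays open; the compounds shown change both at once. Also open, on these data alone, is how a carboxylic acid or a dimethylamino group on this phenyl ring would read.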